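Expecting little change from compound 1 to compound 4

The compounds below may be only part of what the source reports. "The series", "measured", "known", "first", "only" and "open" are said of these compounds alone.

Compound 1 `COc1cc(OC)c(OC)cc1/C=C/C(=O)c1cc(Cl)ccc1O`: 2.32 ug/mL
Compound 2 `COc1cc(OC)c(OC)cc1/C=C/C(=O)c1ccc(Cl)c([N+](=O)[O-])c1`: 1.99 ug/mL
Compound 3 `COc1cc(OC)c(OC)cc1/C=C/C(=O)c1cccc([N+](=O)[O-])c1`: 2.35 ug/mL

In a functional assay, read by Griess assay, with a stated time of 2.5 h (on this read-out lower numbers stand for stronger inhibition and higher numbers for weaker inhibition), all three compounds lie within the scatter of each other, so compound 1, at 2.32 ug/mL, is not separated from compound 2 or compound 3. Compound 4 `COc1cc(OC)c(OC)cc1/C=C/C(=O)c1ccc(O)cc1` is still unmeasured. Its difference from compound 1 is 4-hydroxyphenyl in place of 5-chloro-2-hydroxyphenyl on a carbonyl carbon. Among the compounds with values here, one measured step bears on this, the one with hydrogen in place of chloro: a 1.2-fold higher number from compound 2 to compound 3 (0.07 log units; within the scatter). Within the data shown here, no measured step covers the rest of the change to 4-hydroxyphenyl, so this support is partial. No step beyond the scatter is therefore expected in this assay, and the estimated step is a 1.1-fold higher number from compound 1 to compound 4 (0.03 log units; within the scatter). Compound 4 is expected at 2.5 ug/mL, within an estimated range of 1.2 ug/mL to 5 ug/mL.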

Compound 4, half-maximal inhibitory concentration: 2.5 ug/mL
Compound 4: the middle estimate sits on the measured number at the digits printed, within the range that was stated.
By their numbers in this assay, from the lowest: compounds 2, 1, 3 and 4 (each within the scatter of the next).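

In this assay, replacing 5-chloro-2-hydroxyphenyl with 4-hydroxyphenyl on a carbonyl carbon gives a 1.1-fold higher number from compound 1 to compound 4 (0.03 log units; within the scatter). The earlier step covered only hydrogen in place of chloro, whereas this one exchanges the whole group and still does not separate the two compounds. Nothing available gives a cause for this result.

The compounds shown leave open whether a group of another kind at this place, such as an amine, a carboxylic acid or a longer chain, would give a step beyond the scatter.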